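Carbamoyl for trifluoromethyl on the pendant phenyl

The source may hold more compounds than are shown below. What is called first, only, known or untested is meant among the compounds shown, and "the series" means these compounds.

Measured so far in a physicochemical assay for lipophilicity, at pH 7.4; on this read-out lower numbers stand for lower lipophilicity and higher numbers for higher lipophilicity:
compound 1, `COc1ccc(-c2cc(-c3ccc(NS(C)(=O)=O)cc3)cnc2N)cn1`, gives 2.2
compound 2, `COc1ccc(-c2cc(-c3ccc(S(C)(=O)=O)c(F)c3)cnc2N)cn1`, gives 2.5
compound 3, `COc1ccc(-c2cc(-c3ccc(C(F)(F)F)cc3)cnc2N)cn1`, gives 4.2

Compound 3 stands highest of the three in this assay; its values lie beyond the scatter from both compound 2 and compound 1, and compound 2 sits closer to it than compound 1 does. Compound 4, `COc1ccc(-c2cc(-c3ccc(C(N)=O)cc3)cnc2N)cn1`, is not yet measured. It differs from compound 3 in one place: carbamoyl in place of trifluoromethyl on an aromatic carbon.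

Going by the values given here, the only measured step that bears on this change is the one from compound 1 to compound 3, where a number 2.00 log units higher from compound 1 to compound 3 (beyond the scatter). That step swapped a methanesulfonamido group for trifluoromethyl; the present step runs the other way, replacing trifluoromethyl with a carbamoyl group that also carries one hydrogen-bond donor and one acceptor. Among the compounds with values here, compound 2 offers no single-change step to compound 3, and its value merely shows that another sulfonyl-bearing compound of the series sits well below compound 3.

A large downward step in this assay is therefore expected for compound 4, of about a number 2.20 log units lower from compound 3 to compound 4 (beyond the scatter). Compound 4 is estimated at 2, with a likely range from 1.5 to 2.6.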

Compound 4, distribution coefficient: 1.7
Estimate against measurement, compound 4: 0.30 log units above, and the stated range covers the measured number.
By their numbers in this assay, from the lowest: compound 4; then compounds 1 and 2 (each within the scatter of the next); then compound 3.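

In this assay, carbamoyl in place of trifluoromethyl at this position gives a large step, with a number 2.50 log units lower from compound 3 to compound 4 (beyond the scatter) as the read-out, so a second group now stands far from trifluoromethyl. Carbamoyl is also separated from methanesulfonamido at the same position: a number 0.50 log units lower from compound 1 to compound 4 (beyond the scatter) is a modest step, smaller than the first, yet the two groups do not read as equivalent in this assay. No supporting data here give a reason for either step.

Going by these compounds, whether a carboxylic acid, a primary amine or a nitrile at this position would read close to carbamoyl or close to trifluoromethyl remains open. On these data alone, it also remains open whether the carbamoyl step would keep its size on a core other than the shared core of compound 3 and compound 4.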